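The source may report more compounds than this note shows. Statements on the series, on what has been measured and on what is new or still open speak of the compounds shown alone.

Compound 1 `NCCCNCCCCNCCCNC(=O)[C@H](CC1CCCCC1)NC(=O)C1CCC1` and compound 2 `NCCCNCCCCNCCCNC(=O)[C@H](CC1CCCCC1)NC(=O)C1CCCC1` share a core that carries a polyamine chain and differ only in the ring on the carbonyl carbon of the terminal amide. In an assay on cells for antagonist activity at Neuronal acetylcholine receptor; alpha3/beta4 (Homo sapiens), read by two-electrode voltage clamp, with a stated time of 1 min (a higher number here means a weaker inhibitor, a lower number a stronger inhibitor), compound 1 gives 1.07 nM, and compound 2 gives 0.65 nM; the step of a 1.6-fold lower number from compound 1 to compound 2 (0.22 log units; within the scatter) shows that exchanging one small ring for the next larger one at this position leaves the inhibition essentially unchanged. Among the measured compounds shown here, compound 1 therefore holds the higher of the two numbers measured so far, with compound 2 within the scatter of it.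

Compound 3 `NCCCNCCCCNCCCNC(=O)[C@H](CC1CCCCC1)NC(=O)c1ccc(-c2ccccc2)cc1` carries a change at the same carbonyl carbon: 4-phenylphenyl in place of cyclobutyl on a carbonyl carbon. For the measured compounds named here, the only measured step that bears on it, from compound 1 to compound 2, stayed within the scatter, but it covered a far smaller change. Going by the values given here, no measured step spans the move from a small ring to a biaryl group, so the direction is open. Compound 3 is expected in this assay to give 1.5 nM, within 0.4 nM to 6 nM, a step of a 1.4-fold higher number from compound 1 to compound 3 (0.15 log units; within the scatter) that is estimated to stay close to the scatter.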

Compound 3, half-maximal inhibitory concentration: 2.83 nM
The estimate for compound 3 lay 1.9-fold (0.28 log units) below the measured number; the range from low to high includes it.
By their numbers in this assay, from the lowest: compounds 2 and 1 (each within the scatter of the next); then compound 3.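

The two small rings left open whether this carbonyl carbon responds to a much larger group, and the 4-phenylphenyl group shows that it does: replacing cyclobutyl gives a 2.6-fold higher number from compound 1 to compound 3 (0.42 log units; beyond the scatter) and replacing cyclopentyl gives a 4.4-fold higher number from compound 2 to compound 3 (0.64 log units; beyond the scatter) in this comparison. Both steps are modest, and in this assay compound 3 still gives 2.83 nM as its inhibition value, so a group of 12 heavy atoms in place of 4 is tolerated here at a limited cost. No evidence at hand accounts for this step.

The compounds shown leave open whether a single phenyl group at this carbonyl carbon would stay with the small rings or move toward 4-phenylphenyl. They also leave open how an amine or a carboxylic acid on the group at this place would change the inhibition.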